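Chain extension at the ether of compound 1

This account rests on a few compounds, and the source may have more. Where it says the series, first, only, none or still open, it means among the compounds named here.

Compound 1 `CCOc1ccc2c(=O)c(-c3ccc(O)cc3)coc2c1` gives 86.9% in a functional assay on mitochondria (Cricetulus griseus) for inhibition of Monoamine oxidase (Homo sapiens), tested at 0.9 uM (on this read-out higher numbers stand for a stronger effect at the one concentration tested and lower numbers for a weaker effect), and stands highest of the two numbers recorded; its nearest neighbour is compound 2 `C=CCOc1ccc2c(=O)c(-c3ccc(O)cc3)coc2c1`, which gives 68.8%. Among the compounds with values here, the only measured step, a number 18.1 percentage points lower from compound 1 to compound 2 (beyond the scatter), concerns a small change at the same ether chain. Compound 3 `O=C(O)CCCCCCOc1ccc2c(=O)c(-c3ccc(O)cc3)coc2c1` differs from compound 1 by 4-carboxybutyl in place of hydrogen on a saturated chain carbon, two bonds along the chain from an oxygen on an aromatic ring. That earlier step points downward for a growth of this chain, so a larger loss is expected here, estimated at a number 31.9 percentage points lower from compound 1 to compound 3 (beyond the scatter). Compound 3 is therefore expected to give about 55%, between 30% and 78%.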

Compound 3, a percentage reported as inhibition, at one concentration (the size of the read-out at that concentration, not a potency): 71.2%
The estimate for compound 3 lay 16.2 percentage points below the measured number, within the range that was stated.
By their numbers in this assay, from the lowest: compounds 2 and 3 (each within the scatter of the next); then compound 1.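

In this assay the saturated chain carbon, two bonds along the chain from an oxygen on an aromatic ring, accepts 4-carboxybutyl in place of hydrogen with a number 15.7 percentage points lower from compound 1 to compound 3 (beyond the scatter) and no greater loss than vinyl brought, as a number 2.4 percentage points higher from compound 2 to compound 3 (within the scatter) shows. Among these three compounds, the number does not fall in step with the size of the group on the chain. Nothing given here accounts for this result. Going by these compounds, it remains open whether the number of compound 3 belongs to the chain length or to its terminal carboxylic acid; a plain hexyl chain or a chain ending in an amine would separate the two.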